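A few compounds are considered here, and "the series" means these few. Any claim that something is new, unique, unknown or untested is made for them only; others in the source may bear on it.

Measured compounds:
Compound 1, `COc1ccc(Cn2cc(CSC(=S)N3CCN(C(=O)OCc4ccccc4)CC3)nn2)cc1`, gives 30500 nM in a functional assay on MCF7 cells (Homo sapiens) for inhibition, read by MTT assay, with a stated time of 72 h; a higher number here means a weaker inhibitor, a lower number a stronger inhibitor.
Compound 2, `CC(C)(C)OC(=O)N1CCN(C(=S)SCc2cn(Cc3ccc(Cl)c(Cl)c3)nn2)CC1`, gives 19100 nM in this assay.
Compound 3, `O=C(OCc1ccccc1)N1CCN(C(=S)SCc2cn(Cc3ccc(Cl)c(Cl)c3)nn2)CC1`, gives 10600 nM in this assay.

Compound 4, `COc1ccc(Cn2cc(CSC(=S)N3CCN(C(=O)OC(C)(C)C)CC3)nn2)cc1`, has not yet been measured in this assay. It differs from compound 2 by 4-methoxyphenyl in place of 3,4-dichlorophenyl on a saturated chain carbon bound to an aromatic nitrogen. The same change has already been made once among the measured compounds, from compound 3 to compound 1, where it is described as 4-methoxyphenyl in place of 3,4-dichlorophenyl on a saturated chain carbon bound to an aromatic nitrogen and gave a 2.9-fold higher number from compound 3 to compound 1 (0.46 log units; beyond the scatter). The place of the change is the same in both pairs, so this is the same change made on a second core. The two cores differ by tert-butyl in place of benzyl on an oxygen next to a carbonyl group, a change that gave a 1.8-fold lower number from compound 2 to compound 3 (0.26 log units; within the scatter).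

Resting on the single earlier step, compound 4 is expected to show a 2.6-fold higher number from compound 2 to compound 4 (0.42 log units; beyond the scatter), because from compound 3 to compound 1 the same change gave a 2.9-fold higher number from compound 3 to compound 1 (0.46 log units; beyond the scatter). Compound 4 is therefore estimated at 50000 nM in this assay. Given that only one earlier step supports this, the expected range for compound 4 is wide, from 20000 nM to 120000 nM.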

Compound 4, half-maximal inhibitory concentration: 4960 nM
Beside the measured number, compound 4's estimate is 10-fold (1.00 log units) above it; measured number outside the range, below it.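

In this assay, placing 4-methoxyphenyl where 3,4-dichlorophenyl stood gave a 3.9-fold lower number from compound 2 to compound 4 (0.59 log units; beyond the scatter), so the change did not carry over from one core to the other and its direction reversed: the same change on two cores in this assay, a 2.9-fold higher number (0.46 log units; beyond the scatter) from compound 3 to compound 1 and a 3.9-fold lower number (0.59 log units; beyond the scatter) from compound 2 to compound 4, 11-fold (1.04 log units) apart, beyond the scatter of two such steps The tert-butyl for benzyl change likewise depended on its partner group, giving a 6.1-fold lower number from compound 1 to compound 4 (0.79 log units; beyond the scatter), and it did not match the step made with 3,4-dichlorophenyl in place: the same change on two cores in this assay, a 1.8-fold lower number (0.26 log units; within the scatter) from compound 2 to compound 3 and a 6.1-fold higher number (0.79 log units; beyond the scatter) from compound 4 to compound 1, 11-fold (1.04 log units) apart, beyond the scatter of two such steps These four compounds show that, in this set, the effects of the two changes do not simply add, so neither step can safely be carried to the other core; they do not show why, or whether this holds beyond these groups.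

As far as these compounds go, it remains open whether compound 4 is a special pairing of 4-methoxybenzyl with tert-butyl or part of a wider trend. A plain benzyl in place of 3,4-dichlorobenzyl, or an ethyl on an oxygen next to a carbonyl group, could show whether the reversal extends to other groups.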